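Replacing 4-aminophenyl with 3,4-difluorophenyl on a carbonyl carbon

A few compounds are considered here, and "the series" means these few. Any claim that something is new, unique, unknown or untested is made for them only; others in the source may bear on it.

In a functional assay on IGROV-1 cells (Homo sapiens) for inhibition, read by sulforhodamine B assay, with a stated time of 48 h (a higher number here means that more compound is tolerated, a lower number that less compound is tolerated), compound 1 (`COc1cc(-c2cc(/C=C/C(=O)c3ccc(N)cc3)[nH]n2)cc(OC)c1OC`) gives > 100000 nM, which is a limit of the assay and not a number. Its position is therefore known only as that limit. Compound 3 (`COc1cc(-c2cc(/C=C/C(=O)c3ccc(F)c(F)c3)[nH]n2)cc(OC)c1OC`) keeps the core of compound 1 and carries 3,4-difluorophenyl in place of 4-aminophenyl on a carbonyl carbon, whose other neighbour is a double-bonded chain carbon: 3,4-difluorophenyl in place of 4-aminophenyl on a carbonyl carbon. Within the data shown here, one measured step bears on this change. Compound 2 (`COc1ccc(C(=O)/C=C/c2cc(-c3cc(OC)c(OC)c(OC)c3)n[nH]2)cc1OC`) has 3,4-dimethoxyphenyl at the same place and gives 6480 nM in this assay. The step there is an at least 15-fold lower number from compound 1 to compound 2 (1.18 log units; beyond the scatter), so leaving 4-aminophenyl was large in that single case, and it ran towards a lower number. Among the measured compounds shown here, this is only one example, and its entering group differs from 3,4-difluorophenyl, so a smaller move is expected here, in the same direction, and compound 3 may also stay at a limit. The expected step is an at least 5.0-fold lower number from compound 1 to compound 3 (0.69 log units; beyond the scatter). For compound 3 the estimated value is 20000 nM, with an expected range from 5000 nM to 80000 nM.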

Compound 3, concentration lethal to 50% of the cells: > 100000 nM
Compound 3 ended at the assay's limit; the forecaster's own chance of this, stated with the estimate: 25%; at least 5.0-fold (0.69 log units) between middle value and limit.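

In this assay compound 3 gives > 100000 nM, which is a limit of the assay and not a number. On a carbonyl carbon, 3,4-difluorophenyl in place of 3,4-dimethoxyphenyl gives an at least 15-fold higher number from compound 2 to compound 3 (1.18 log units; beyond the scatter), so removing 4-aminophenyl does not by itself bring the number down, and among the three groups shown at this place, only 3,4-dimethoxyphenyl gives a readable value. The step between compound 1 and compound 3 cannot be read, and the comparison at this place therefore rests on compound 2 alone, with compound 1 and compound 3 both at the same boundary of the read-out: the limit of > 100000 nM in this assay, at which 2 of the 3 values shown sit.

The compounds shown leave open whether the two methoxy groups of compound 2 are both needed, since a phenyl group with a single methoxy group, or with hydroxyl groups in their place, does not appear among them. They also leave open whether any other group at this place, such as a 4-chlorophenyl or an unsubstituted phenyl, would give a readable value in this assay on the core of compound 1.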